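The source may hold more compounds than are shown below. What is called first, only, known or untested is meant among the compounds shown, and "the series" means these compounds.

Compound 1 `CC1=C(C(=O)OCC(C)C)C(c2cc([N+](=O)[O-])ccc2O)C2=C(CCC(C)(C)C2=O)N1` gives 70% in an assay for inhibition of Voltage-dependent L-type calcium channel subunit alpha-1C (Rattus norvegicus), read by patch clamp, tested at 10 uM; a higher number here means more inhibition at the concentration tested (going by the name of the read-out), a lower number less inhibition. Compound 2 `COC(=O)C1=C(C)NC2=C(C(=O)C(C)(C)CC2)C1c1cc([N+](=O)[O-])ccc1O` reaches only the assay limit of < 30% in this assay.

Compound 1 thus stands as the only number shown; the other value is a limit (the limit of < 30% in this assay, at which 1 of the 2 values shown sits). Compound 3 `CC1=C(C(=O)OCC(C)C)C(c2cc([N+](=O)[O-])cc(Br)c2O)C2=C(CCC(C)(C)C2=O)N1` differs from compound 1 by bromo in place of hydrogen on an aromatic carbon. For the measured compounds named here, the single measured step, a number at least 40 percentage points lower from compound 1 to compound 2 (beyond the scatter), concerns the saturated chain carbon bound to an oxygen, not the aromatic ring, so it bears little on this change. Going by the values given here, no measured step addresses bromo on the ring, and compound 3 is therefore expected to shift by a number 5 percentage points lower from compound 1 to compound 3 (within the scatter), within the scatter. Compound 3 is estimated at 65%, ranging from 35% to 90%.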

Compound 3, a percentage reported as inhibition, at one concentration (the size of the read-out at that concentration, not a potency): 15%
The estimate for compound 3 lay 50 percentage points above the measured number, outside the stated range (below it).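

On the aromatic carbon ortho to a hydroxy group and meta to a nitro group, bromo in place of hydrogen has a clear cost in this assay: a number 55 percentage points lower from compound 1 to compound 3 (beyond the scatter). For the compounds shown here, the only earlier step lay on the saturated chain, so this is the first sign that this ring carbon, too, moves the read-out. Nothing shown gives a cause for this loss.

On these data alone, whether the loss belongs to bromo itself or would also follow fluoro, a methoxy group or an amine on this carbon stays open. So does whether bromo would act alike alongside the chain of compound 2.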